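Ring in Place of Chain on a Cytotoxicity Scaffold

A few compounds are considered here, and "the series" means these few. Any claim that something is new, unique, unknown or untested is made for them only; others in the source may bear on it.

Compound 2 `C=C(CCC=C(C)C)C(O)Cc1c(O)ccc2c1O[C@H](c1ccc(O)cc1)CC2=O` has been tested in a functional assay on HeLa S3 cells (Homo sapiens) for cytotoxicity, read by MTT assay; on this read-out lower numbers stand for stronger inhibition and higher numbers for weaker inhibition. In this assay compound 2 gives > 10000 nM, which is a limit of the assay and not a number. Its near relative compound 1 `C=C(C)C(O)CC/C(C)=C/Cc1c(O)ccc2c1O[C@H](c1ccc(O)cc1)CC2=O` differs from it only in the side chain. In this assay compound 1 also gives > 10000 nM, again a limit of the assay and not a number. The step that the two limits leave unreadable from compound 1 to compound 2 therefore cannot be read in size or direction. Compound 3 `CC1=CCC(O)C(C)(C)C1Cc1c(O)ccc2c1O[C@H](c1ccc(O)cc1)CC2=O` is not yet measured; it carries a group of 10 heavy atoms (9 carbon, 1 oxygen; one six-membered non-aromatic ring of carbon only) in place of a group of 10 heavy atoms (9 carbon, 1 oxygen; no ring), on a saturated chain carbon bound to an aromatic carbon. Going by the values given here, the single measured step offers no size and no direction, so the only guide is the limit of > 10000 nM in this assay, at which 2 of the 2 values shown sit. For the step that the limit leaves unreadable from compound 2 to compound 3 no change beyond the scatter is expected. Compound 3 is estimated to give 15000 nM in this assay, with a range from 4000 nM to 60000 nM, and the result is expected most likely to be reported again as a limit.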

Compound 3, half-maximal inhibitory concentration: > 10000 nM
Compound 3 was reported as a limit; the forecaster's own chance of this, stated with the estimate: 80%; the middle value does not contradict the limit.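

Compound 1, compound 2 and compound 3 all sit at a limit of the assay and not at a number, so no step among them can be read in size or direction: the limit of > 10000 nM in this assay, at which 3 of the 3 values shown sit.

The compounds shown leave open how strongly any of the three acts in this assay, and whether the ring in place of the chain makes any difference there.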